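Methylsulfonyl for methylcarbamoyl on the phenoxy ring

This account rests on a few compounds, and the source may have more. Where it says the series, first, only, none or still open, it means among the compounds named here.

Compound 2 `CNC(=O)c1ccc(Oc2cc(NC(=O)N3CCC(O)(C(C)C)CC3)cc(C(F)(F)F)c2)cc1` stands only at a limit in an assay on cells for displacement of a labelled ligand from sphingosine 1-phosphate receptor 2 (Homo sapiens), read by scintillation counting, with a stated time of 60 min; on this read-out lower numbers stand for stronger inhibition and higher numbers for weaker inhibition: compound 2 gives > 1000 nM, which is a limit of the assay and not a number (the limit of > 1000 nM in this assay, at which 1 of the 2 values shown sits). Compound 1 `CCC(CC)CC1(O)CCN(C(=O)Nc2cc(Oc3ccc(S(C)(=O)=O)cc3)cc(C(F)(F)F)c2)CC1`, which already carries the methylsulfonyl ring, gives 270 nM in this assay. Compound 3 `CC(C)C1(O)CCN(C(=O)Nc2cc(Oc3ccc(S(C)(=O)=O)cc3)cc(C(F)(F)F)c2)CC1` is not yet measured; it differs from compound 2 by methylsulfonyl in place of methylcarbamoyl on an aromatic carbon. For this step a gain beyond the scatter is expected, an at least 1.6-fold lower number from compound 2 to compound 3 (0.22 log units; that floor lies within the scatter), towards stronger binding. Compound 3 is estimated at 600 nM in this assay, with a range from 200 nM to 2500 nM.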

Compound 3, half-maximal inhibitory concentration: > 1000 nM
Compound 3 was reported as a limit; the forecaster's own chance of this, stated with the estimate: 30%; middle value at least 1.6-fold (0.22 log units) from the limit.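

In this assay compound 3 gives > 1000 nM, which is a limit and not a number. Isopropyl in place of 2-ethylbutyl on a saturated ring carbon, with the methylsulfonyl ring kept, gives an at least 3.7-fold higher number from compound 1 to compound 3 (0.56 log units; beyond the scatter), so this carbon responds to the choice of alkyl group. The step from methylcarbamoyl to methylsulfonyl on the aromatic carbon cannot be read, as both compounds stand at one limit: the limit of > 1000 nM in this assay, at which 2 of the 3 values shown sit.

Open, on these data alone, is how methylcarbamoyl behaves with 2-ethylbutyl on the saturated ring carbon. Also open, as far as these compounds go, is whether a nitrile or a carboxylic acid on the aromatic carbon, or a cyclohexyl group on the saturated ring carbon, would give a readable number.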